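The compounds below may be only part of what the source reports. "The series", "measured", "known", "first", "only" and "open" are said of these compounds alone.

Measured so far:
- compound 2, `OCc1cc(Br)c(O)c(O)c1Br`: 21400 nM in a functional assay on HCT-116 cells (Homo sapiens) for cytotoxicity, read by MTT assay, with a stated time of 96 h; on this read-out lower numbers stand for stronger inhibition and higher numbers for weaker inhibition
- compound 1, `OCc1cc(O)c(O)c(Br)c1`: "not determined" (no result reported) in this assay
- compound 3, `COCc1cc(O)c(O)c(Br)c1`: "not determined" (no result reported) in this assay

Compound 2 therefore stands alone. It is the only number shown; the other two entries carry no value, so nothing in this set can be set beside it for comparison. Compound 4, `CCOCc1cc(Br)c(O)c(O)c1Br`, has not yet been measured. It differs from compound 2 in a single place: ethyl in place of hydrogen on an oxygen on a saturated carbon. Among the compounds with values here, no step between measured compounds is recorded, so this set offers no example of how such a change shifts the read-out. The expected step is a 1.2-fold lower number from compound 2 to compound 4 (0.08 log units; within the scatter), which is none beyond the usual scatter. Compound 4 is accordingly estimated at 18000 nM, in the range 6000 nM to 60000 nM.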

Compound 4, half-maximal inhibitory concentration: 1540 nM
For compound 4 the middle estimate is 12-fold (1.07 log units) above the measured one; measured number below the stated range.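

Replacing hydrogen with ethyl on this oxygen, which turns hydroxymethyl into ethoxymethyl, gives a 14-fold lower number from compound 2 to compound 4 (1.14 log units; beyond the scatter) in this assay. Within the data shown here, this is the first sign that the position responds to change, and that capping the hydroxy group does not cost activity here. Nothing measured here explains why the step is so large.

As far as these compounds go, whether a longer chain such as propyl or butyl on this oxygen would lower the number further remains open. So does the outcome of putting an amine or a carboxylic acid at this place.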